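The source may hold more compounds than are shown below. What is called first, only, known or untested is meant among the compounds shown, and "the series" means these compounds.

Working notes on the series: in an ADME assay on liver for metabolic stability, with Liver microsome (Homo sapiens) as the target, read by LC-MS, using microsomes (a higher number here means faster removal of the compound, a lower number slower removal), every compound read so far returns only a limit of the assay, not a number. Compound 1 `CC(C)(C)[C@@H](O)C(=O)N1C[C@@H]2C[C@@H]2[C@H]1C(=O)NCc1cc(Cl)ccc1-n1cnnn1` gives < 15 mL.min-1.g-1, a limit. Compound 3 `CCCC[C@@H](O)C(=O)N1N=CC[C@H]1C(=O)NCc1cc(Cl)ccc1-n1cnnn1` gives < 12 mL.min-1.g-1, also a limit. Compound 2 `CC(C)(C)[C@@H](O)C(=O)N1OCC[C@H]1C(=O)NCc1cc(Cl)ccc1-n1cnnn1` gives < 12 mL.min-1.g-1, again a limit, so its place among the three cannot be ranked. Compound 4 `CC(C)(C)C[C@@H](O)C(=O)N1OCC[C@H]1C(=O)NCc1cc(Cl)ccc1-n1cnnn1` has neopentyl in place of tert-butyl on a saturated chain carbon bound to a carbonyl carbon and an oxygen on a saturated carbon. Going by the values given here, no measured pair isolates this change. The expected a number no lower from compound 2 to compound 4 (the limit leaves the size open) is small, within the usual scatter, and if anything towards faster removal. Compound 4 is estimated at 12 mL.min-1.g-1, with an expected range of 8 mL.min-1.g-1 to 24 mL.min-1.g-1.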

Compound 4, intrinsic clearance in microsomes: < 12 mL.min-1.g-1
Compound 4 gave a limit, no number; the forecaster's own chance of this, stated with the estimate: 65%; the middle value sits exactly at the limit.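

Going by these compounds alone, compound 2 and compound 4 each return only a limit in this assay, so no step between them can be read. The compounds shown leave open how neopentyl and tert-butyl compare, and how fast any of these compounds is actually removed.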